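Ester chain length and hydrolytic half-life of compound 4

A few compounds are considered here, and "the series" means these few. Any claim that something is new, unique, unknown or untested is made for them only; others in the source may bear on it.

Compound 1 `CO[C@H]1C(=O)N2C(C(=O)C(C)(C)C)=C(C)[C@@H](OC=O)S(=O)(=O)C12`: in a physicochemical assay, at pH 7.4 (on this read-out lower numbers stand for a shorter-lived compound and higher numbers for a longer-lived compound), compound 1 gives < 0.5 h, which is a limit of this assay, not a number.
Compound 2 `CO[C@H]1C(=O)N2C(C(=O)C(C)(C)C)=C(C)[C@@H](OC(C)=O)S(=O)(=O)C12`: in this assay compound 2 gives 6.3 h.
Compound 3 `CO[C@H]1C(=O)N2C(C(=O)C(C)(C)C)=C(C)[C@@H](OC(=O)C(C)(C)C)S(=O)(=O)C12`: in this assay compound 3 gives 54 h.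

Compound 3 stands highest among the numbers shown; the nearest is compound 2, and the step of an 8.6-fold higher number from compound 2 to compound 3 (0.93 log units; beyond the scatter) is beyond the scatter. The unmeasured compound 4 `CO[C@H]1C(=O)N2C(C(=O)C(C)(C)C)=C(C)[C@@H](OC(=O)CCC(=O)c3ccccc3)S(=O)(=O)C12` differs from compound 3 by 2-benzoylethyl in place of tert-butyl on a carbonyl carbon.

The measured steps all alter the group on this same carbonyl carbon. The change from hydrogen to methyl gave an at least 12-fold higher number from compound 1 to compound 2 (1.10 log units; beyond the scatter), from hydrogen to tert-butyl an at least 100-fold higher number from compound 1 to compound 3 (2.03 log units; beyond the scatter), and from methyl to tert-butyl an 8.6-fold higher number from compound 2 to compound 3 (0.93 log units; beyond the scatter). The change to compound 4 removes the tert-butyl and puts in a 2-benzoylethyl chain, which, like the methyl of compound 2, carries hydrogens on the carbon attached to the carbonyl. On that basis the half-life of compound 4 is expected to fall below that of compound 3 and nearer to compound 2, a step of a 6.0-fold lower number from compound 3 to compound 4 (0.78 log units; beyond the scatter). Compound 4 is therefore estimated at 9 h, within a range from 3 h to 25 h.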

Compound 4, half-life: 13 h
For compound 4 the middle estimate is 1.4-fold (0.16 log units) below the measured one; low and high end bracket the measured number.
By their numbers in this assay, from the lowest: compound 2; then compound 4; then compound 3. At a limit, below all of these: compound 1.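

In this assay, 2-benzoylethyl in place of tert-butyl on a carbonyl carbon gives a 4.2-fold lower number from compound 3 to compound 4 (0.62 log units; beyond the scatter), so this longer chain does not keep the half-life seen with tert-butyl, even though it enters with more heavy atoms than tert-butyl takes away. Set against the methyl ester, the same chain gives a 2.1-fold higher number from compound 2 to compound 4 (0.31 log units; beyond the scatter), a modest step that places compound 4 between compound 2 and compound 3 and shows that the half-life at this position does not simply follow from the methyl and tert-butyl results. The step from the formyl end of the series, an at least 26-fold higher number from compound 1 to compound 4 (1.41 log units; beyond the scatter), is a bound and not a size, for it starts from a limit of the assay: the limit of < 0.5 h in this assay, at which 1 of the 4 values shown sits.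

The compounds shown leave open which part of the 2-benzoylethyl chain sets it apart from methyl, the benzoyl end or the chain length alone, which a plain propyl or butyl chain would help to separate. They also leave open how a methyl branch on this chain, or an amine or a carboxylic acid at its end, would move the half-life in this assay.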